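The compounds below may be only part of what the source reports. "The series", "measured", "known", "first", "only" and "open" are said of these compounds alone.

Measured in a functional assay on U-87MG ATCC cells for antiproliferative activity against U-87 MG (Homo sapiens), read by MTT assay, with a stated time of 48 h; a lower number here means a stronger inhibitor, a higher number a weaker inhibitor:
- compound 1 `COc1ccc(-c2nc(C)c(C(=O)CSc3nc(-c4ccc(OC)c(OC)c4)c(C#N)c(=O)[nH]3)s2)cc1`: 12500 nM
- compound 2 `Cc1nc(-c2ccccc2)sc1C(=O)CSc1nc(-c2ccc(Cl)c(Cl)c2)c(C#N)c(=O)[nH]1`: 65000 nM
- compound 3 `Cc1nc(-c2ccccc2)sc1C(=O)CSc1nc(-c2ccccc2)c(C#N)c(=O)[nH]1`: 56600 nM

Compound 3 at 56600 nM lies within the scatter of compound 2, and both numbers stand clearly higher than that of compound 1.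

The next compound to consider is compound 4 `COc1ccc(-c2nc(SCC(=O)c3sc(-c4ccccc4)nc3C)[nH]c(=O)c2C#N)cc1OC`, which has 3,4-dimethoxyphenyl in place of phenyl on an aromatic carbon of the shared core, ortho to a cyano group: 3,4-dimethoxyphenyl in place of phenyl on an aromatic carbon.

For the measured compounds named here, the only measured step at this place is a 1.1-fold lower number from compound 2 to compound 3 (0.06 log units; within the scatter). It stays within the scatter, so swapping 3,4-dichlorophenyl for phenyl there shows no measurable effect in this assay. That step says nothing directly about 3,4-dimethoxyphenyl. Of the measured compounds, only compound 1 carries this group, at 12500 nM, but compound 1 is not a one-place match to compound 4. It therefore offers only a weak hint towards a lower number.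

The expected change is modest and its size is uncertain: a 2.1-fold lower number from compound 3 to compound 4 (0.32 log units; beyond the scatter), an estimated move towards a lower number. For compound 4 the estimated value is 27000 nM, with an expected range from 11000 nM to 65000 nM.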

Compound 4, half-maximal inhibitory concentration: 15300 nM
The estimate for compound 4 lay 1.8-fold (0.25 log units) above the measured number; the measured number falls inside the stated range.
By their numbers in this assay, from the lowest: compounds 1 and 4 (each within the scatter of the next); then compounds 3 and 2 (each within the scatter of the next).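

Working notes: in this assay, the aromatic carbon ortho to a cyano group now shows a response to its substituent. Here 3,4-dimethoxyphenyl in place of phenyl gives a modest step beyond the scatter (a 3.7-fold lower number from compound 3 to compound 4 (0.57 log units; beyond the scatter)), and 3,4-dimethoxyphenyl in place of 3,4-dichlorophenyl gives a similar one (a 4.2-fold lower number from compound 2 to compound 4 (0.63 log units; beyond the scatter)), whereas the exchange between the other two groups stayed within the scatter (a 1.1-fold lower number from compound 2 to compound 3 (0.06 log units; within the scatter)). The step for hydrogen in place of methoxy on an aromatic carbon also lies within the scatter (a 1.2-fold higher number from compound 1 to compound 4 (0.09 log units; within the scatter)), so that methoxy has no measurable effect in this assay, and no measured property is available to account for any of these steps.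

Still open, going by these compounds, is whether both methoxy groups of 3,4-dimethoxyphenyl are needed at this position, or whether a single methoxy, a hydroxyl or an amine on that phenyl would give a similar number. Also open, on these data alone, is whether a longer chain such as ethoxy in place of methoxy would move the number further in this assay.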